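The source may hold more compounds than are shown below. What is called first, only, known or untested is meant among the compounds shown, and "the series" means these compounds.

In a functional assay on A549 cells (Homo sapiens) for cytotoxicity, read by MTT assay, with a stated time of 48 h (a higher number here means a weaker inhibitor, a lower number a stronger inhibitor), three compounds sharing one core have been measured, and they differ only in the group on a carbonyl carbon. Compound 1 `C=C1C(=O)O[C@H]2CC3=C[C@H](C/C(C)=C/[C@@H](OC(=O)c4ccc([N+](=O)[O-])cc4)[C@H]12)OC3=O`, which carries 4-nitrophenyl, gives > 10000 nM, and this is a limit of the assay rather than a number. Compound 2 `C=C1C(=O)O[C@H]2CC3=C[C@H](C/C(C)=C/[C@@H](OC(=O)/C=C/c4cccc(OC)c4)[C@H]12)OC3=O` gives 6200 nM. Compound 3 `C=C1C(=O)O[C@H]2CC3=C[C@H](C/C(C)=C/[C@@H](OC(=O)C4CCC(F)(F)CC4)[C@H]12)OC3=O` gives 6400 nM, which places it level with compound 2 within the scatter.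

Compound 4 `C=C1C(=O)O[C@H]2CC3=C[C@H](C/C(C)=C/[C@@H](OC(=O)C45CCC(C)(C(=O)O4)C5(C)C)[C@H]12)OC3=O` keeps the core and changes that group again: a group of 11 heavy atoms (9 carbon, 2 oxygen; one five-membered non-aromatic ring of carbon only, one five-membered non-aromatic ring with 1 hetero atom) in place of a group of 8 heavy atoms (6 carbon, 2 fluorine; one six-membered non-aromatic ring of carbon only), on a carbonyl carbon. Two measured steps away from the limit are an at least 1.6-fold lower number from compound 1 to compound 2 (0.20 log units; that floor lies within the scatter) and an at least 1.5-fold lower number from compound 1 to compound 3 (0.19 log units; that floor lies within the scatter), and they say little about size. The more useful comparison is between two quite different groups at this place, which gave a 1.0-fold higher number from compound 2 to compound 3 (0.01 log units; within the scatter). No step beyond the scatter is therefore expected in this assay, although a result at the limit would be possible. The estimated step is a 1.1-fold higher number from compound 3 to compound 4 (0.04 log units; within the scatter). Compound 4 is expected at about 7000 nM, with an estimated range of 3000 nM to 14000 nM.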

Compound 4, half-maximal inhibitory concentration: 3400 nM
Compound 4: the middle estimate sits 2.1-fold (0.31 log units) above what was measured, and the stated range covers the measured number.
By their numbers in this assay, from the lowest: compounds 4, 2 and 3 (each within the scatter of the next). At a limit, above all of these: compound 1.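

At this position the new group gives an at least 2.9-fold lower number from compound 1 to compound 4 (0.46 log units; beyond the scatter), the first step away from compound 1 that clears the scatter, though it is only a floor. Compound 1 stands at a limit of the assay, not at a number: the limit of > 10000 nM in this assay, at which 1 of the 4 values shown sits.

Among the groups with numbers, the change gives a 1.9-fold lower number from compound 3 to compound 4 (0.27 log units; within the scatter) and a 1.8-fold lower number from compound 2 to compound 4 (0.26 log units; within the scatter), so in this assay the group with two five-membered rings and 2 hydrogen-bond acceptors stands level with 4,4-difluorocyclohexyl, which has none, and with the group of compound 2. From the compounds shown here alone, how far compound 1 truly lies from the other three stays open, since its true value is unknown. Also open, going by these compounds, is whether an amine, a carboxylic acid or a longer alkyl chain on this carbonyl carbon would give a step beyond the scatter from compound 2, compound 3 or compound 4.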